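A few compounds are considered here, and "the series" means these few. Any claim that something is new, unique, unknown or untested is made for them only; others in the source may bear on it.

Measured so far in a functional assay on HeLa cells (Homo sapiens) for inhibition; on this read-out lower numbers stand for stronger inhibition and higher numbers for weaker inhibition: compound 1 `OC[C@H]1OC(n2cnc3c(-c4ccco4)ncnc32)[C@H](O)[C@@H]1O` gives 25000 nM, and compound 2 `Cc1csc(-c2ncnc3c2ncn3C2O[C@H](CO)[C@@H](O)[C@H]2O)c1` gives 11400 nM.

Compound 2 holds the lower of these two numbers. Among the compounds with values here, the single measured step is a 2.2-fold lower number from compound 1 to compound 2 (0.34 log units; beyond the scatter), a modest move at the same aromatic carbon.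

Compound 3 `OC[C@H]1OC(n2cnc3c(-c4ccc(O)cc4)ncnc32)[C@H](O)[C@@H]1O` differs from compound 2 by 4-hydroxyphenyl in place of 4-methylthiophen-2-yl on an aromatic carbon. Only a 2.2-fold lower number from compound 1 to compound 2 (0.34 log units; beyond the scatter) touches that position, and it concerns a different replacement, so it gives only a loose guide. A step of similar modest size, in either direction, is expected in this assay. Compound 3 is estimated at 16000 nM, within 4000 nM to 60000 nM. That estimate amounts to a 1.4-fold higher number from compound 2 to compound 3 (0.15 log units; within the scatter).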

Compound 3, half-maximal inhibitory concentration: 32500 nM
Beside the measured number, compound 3's estimate is 2.0-fold (0.31 log units) below it; the range from low to high includes it.
By their numbers in this assay, from the lowest: compound 2; then compounds 1 and 3 (each within the scatter of the next).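

In this assay, the 4-hydroxyphenyl group does not keep the gain seen with 4-methylthiophen-2-yl on this aromatic carbon, giving a 2.9-fold higher number from compound 2 to compound 3 (0.45 log units; beyond the scatter) in this comparison. Set against furan-2-yl, the same group gives a 1.3-fold higher number from compound 1 to compound 3 (0.11 log units; within the scatter) and so cannot be told apart from it. Among these three compounds, only compound 2 stands clear of the others, so a six-membered aromatic ring here is no worse than furan-2-yl. On these data alone, it remains open whether an amine or a carboxylic acid at this aromatic carbon would shift the number. Nothing given here explains why compound 2 stands apart.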